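The compounds below may be only part of what the source reports. "The series", "measured", "known", "first", "only" and "open" are said of these compounds alone.

Compound 1 `CN(Cc1ccc(Cl)cc1)c1cc(C(=O)Nc2ccccc2)ncn1`: < 5000 nM, a limit
Compound 2 `CN(Cc1ccc(C#N)cc1)c1cc(C(=O)Nc2ccccc2)ncn1`: < 5000 nM, a limit

Both compounds were tested in a physicochemical assay for solubility, using the shake flask method, measured as kinetic solubility, with a stated time of 2 h, at pH 7.4 (on this read-out lower numbers stand for lower solubility and higher numbers for higher solubility), and neither has yielded a number. Compound 2 stands only at a limit, < 5000 nM. The two compounds share that same limit: the limit of < 5000 nM in this assay, at which 2 of the 2 values shown sit.

Compound 3 `CN(Cc1cccnc1)c1cc(C(=O)Nc2ccccc2)ncn1` keeps the shared core and differs from compound 2 in one place, with pyridin-3-yl in place of 4-cyanophenyl on a saturated chain carbon bound to a nitrogen on an aromatic ring.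

Among the compounds with values here, only one measured step bears on this change, the swap of cyano in place of chloro on an aromatic carbon. That step, a step that the two limits leave unreadable from compound 1 to compound 2, concerns the group that leaves, but it offers no size to carry over. Within the data shown here, no step of known size or direction can therefore be expected in this assay, and compound 3 may well be reported as a limit again. The expected step, a number no lower from compound 2 to compound 3 (the limit leaves the size open), is accordingly a cautious estimate anchored on that limit. For compound 3 the estimated value is 5000 nM, with an expected range from 1500 nM to 30000 nM.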

Compound 3, solubility: 150000 nM
For compound 3 the middle estimate is 30-fold (1.48 log units) below the measured one; measured number outside the range, above it.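

In this assay, the place on a saturated chain carbon bound to a nitrogen on an aromatic ring proves sensitive to the group it carries: pyridin-3-yl in place of 4-cyanophenyl gives an at least 30-fold higher number from compound 2 to compound 3 (1.47 log units; beyond the scatter), and pyridin-3-yl in place of 4-chlorophenyl gives an at least 30-fold higher number from compound 1 to compound 3 (1.47 log units; beyond the scatter). Both steps lie beyond the scatter, and each start is a limit, so they give only the least size of the change. Within the data shown here, compound 3 is the only one of the three compounds with a number rather than a limit, and it stands apart from the level shared by the other two: the limit of < 5000 nM in this assay, at which 2 of the 3 values shown sit.

The step from compound 1 to compound 2 still cannot be read, so the compounds shown do not separate the chloro and cyano groups from each other at all. Going by these compounds, whether the ring nitrogen of pyridin-3-yl alone carries this step stays open, as does whether pyridin-4-yl, or a phenyl ring bearing a morpholine or a carboxylic acid, would give a step of similar size at this place.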